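A few compounds are considered here, and "the series" means these few. Any claim that something is new, unique, unknown or untested is made for them only; others in the source may bear on it.

Three compounds share one core and differ only in the group on a sulfonyl sulfur. Compound 1 `CCCCS(=O)(=O)Nc1cc(-c2ccc3ncnc(NCCN(C)C)c3c2)cnc1OC` gives 3240 nM in a functional assay on MCF7 cells (Homo sapiens) for antiproliferative activity, read by sulforhodamine B assay, with a stated time of 72 h; a higher number here means a weaker inhibitor, a lower number a stronger inhibitor. Compound 2 `COc1ncc(-c2ccc3ncnc(NCCN(C)C)c3c2)cc1NS(C)(=O)=O` carries hydrogen in place of propyl on a saturated chain carbon bound to the sulfonyl sulfur, and in this assay compound 2 gives 14700 nM; the step is a 4.5-fold higher number from compound 1 to compound 2 (0.66 log units; beyond the scatter). Compound 3 `COc1ncc(-c2ccc3ncnc(NCCN(C)C)c3c2)cc1NS(=O)(=O)c1ccc(F)cc1F` carries 2,4-difluorophenyl on the sulfonyl sulfur, and in this assay compound 3 gives 1020 nM, the lowest of the three numbers, reached by the steps of a 3.2-fold lower number from compound 1 to compound 3 (0.50 log units; beyond the scatter) and a 14-fold lower number from compound 2 to compound 3 (1.16 log units; beyond the scatter).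

Compound 4 `COc1ncc(-c2ccc3ncnc(NCCCN(C)C)c3c2)cc1NS(=O)(=O)c1ccc(F)cc1F` has not yet been measured. It keeps the sulfonyl group of compound 3 and changes the other side of the core: (dimethylamino)methyl in place of dimethylamino on a saturated chain carbon, two bonds along the chain from a nitrogen on an aromatic ring. For the measured compounds named here, none of the measured steps touch this part of the molecule; all three concern the group on the sulfonyl sulfur, so they say nothing about this chain. Going by the values given here, with no step bearing on the change, a step no larger than the scatter is expected, in either direction. Compound 4 is therefore estimated at 1000 nM, with a range from 400 nM to 2500 nM. For compound 4 this means an expected step of a 1.0-fold lower number from compound 3 to compound 4 (0.01 log units; within the scatter).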

Compound 4, half-maximal inhibitory concentration: 3660 nM
For compound 4 the middle estimate is 3.7-fold (0.56 log units) below the measured one, outside the stated range (above it).
By their numbers in this assay, from the lowest: compound 3; then compounds 1 and 4 (each within the scatter of the next); then compound 2.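

For the compounds shown here, compound 4 gives the first reading on the chain that carries the dimethylamino group, since every earlier step changed only the group on the sulfonyl sulfur. Going from (2-(dimethylamino)ethyl)amino to (3-(dimethylamino)propyl)amino, with the 2,4-difluorophenyl group kept in place, gives a 3.6-fold higher number from compound 3 to compound 4 (0.55 log units; beyond the scatter) in this assay and so makes the inhibitor weaker: this chain is not a neutral part of the molecule, and its length alone can move the result, at least in this single pair. Nothing shown here bears on the cause of this step.

The compounds shown leave open whether a still longer chain, such as 4-(dimethylamino)butyl, would continue in the same direction, and whether a morpholine or a hydroxyl group in place of dimethylamino would give a stronger or a weaker inhibitor than either chain tested so far. They also leave open whether the same extension of the chain would move the number the same way and by a similar amount with butyl or methyl on the sulfonyl sulfur instead of 2,4-difluorophenyl.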